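The compounds below may be only part of what the source reports. "The series", "measured", "known", "first", "only" and "open" are said of these compounds alone.

Measured so far in a functional assay on MGC-803 cells (Homo sapiens) for antiproliferative activity, read by MTT assay, with a stated time of 48 h; on this read-out lower numbers stand for stronger inhibition and higher numbers for weaker inhibition:
Compound 1 `COc1ccc(CN(C(=O)CSc2nc3ccccc3s2)c2cc(OC)c(OC)c(OC)c2)cc1F` gives 416 nM.
Compound 2 `COc1cc(N(Cc2ccc(C)cc2)C(=O)CSc2nc3ccccc3s2)cc(OC)c1OC` gives 54200 nM.
Compound 3 `COc1cc(N(Cc2ccc(Br)cc2)C(=O)CSc2nc3ccccc3s2)cc(OC)c1OC` gives 48100 nM.

Compound 1 has the lowest number of the three, and its steps to both other compounds lie beyond the scatter, so it stands as the most potent of this set in this assay. Compound 4 `COc1cc(CN(C(=O)CSc2nc3ccccc3s2)c2cc(OC)c(OC)c(OC)c2)cc(OC)c1OC` is not yet measured and differs from compound 1 in one place only: 3,4,5-trimethoxyphenyl in place of 3-fluoro-4-methoxyphenyl on a saturated chain carbon bound to an amide-type nitrogen.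

For the measured compounds named here, two measured steps bear on this change, since both also remove the 3-fluoro-4-methoxyphenyl from the saturated chain carbon bound to the amide-type nitrogen. a 130-fold higher number from compound 1 to compound 2 (2.11 log units; beyond the scatter) and a 120-fold higher number from compound 1 to compound 3 (2.06 log units; beyond the scatter). Between the two replacements, a 1.1-fold lower number from compound 2 to compound 3 (0.05 log units; within the scatter), so they behave alike. Going by the values given here, neither 4-methylphenyl nor 4-bromophenyl carries a methoxy group, whereas the entering 3,4,5-trimethoxyphenyl is itself a methoxy-bearing ring; no measured step tests such a replacement, so the outcome is uncertain. Compound 4 is expected to show a higher number than compound 1, though a smaller rise than those seen for compound 2 and compound 3. The step for compound 4 is estimated as a 3.6-fold higher number from compound 1 to compound 4 (0.56 log units; beyond the scatter). Compound 4 is estimated at 1500 nM, with a range from 250 nM to 15000 nM.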

Compound 4, half-maximal inhibitory concentration: 45700 nM
Beside the measured number, compound 4's estimate is 30-fold (1.48 log units) below it; the measured number lies above the stated range.
By their numbers in this assay, from the lowest: compound 1; then compounds 4, 3 and 2 (each within the scatter of the next).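

A methoxy-bearing ring on the saturated chain carbon bound to an amide-type nitrogen does not by itself keep the low number of compound 1: in this assay, 3,4,5-trimethoxyphenyl in place of 3-fluoro-4-methoxyphenyl gives a 110-fold higher number from compound 1 to compound 4 (2.04 log units; beyond the scatter). Beside the two earlier replacements the new ring stays within the scatter, with a 1.1-fold lower number from compound 3 to compound 4 (0.02 log units; within the scatter) and a 1.2-fold lower number from compound 2 to compound 4 (0.07 log units; within the scatter), so 4-methylphenyl, 4-bromophenyl and 3,4,5-trimethoxyphenyl now form one group at this place, and compound 1, the only compound carrying 3-fluoro-4-methoxyphenyl, stands alone. Nothing available accounts for this separation of compound 1 from the other three.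

For the compounds shown here, open remains how much of the low number of compound 1 rests on the fluoro, as no compound here has a chloro, a hydroxy or an amino group in its stead on an otherwise unchanged ring. Also open, as far as these compounds go, is whether other rings at this place, such as a pyridine or a thiophene, would group with compound 1 or with compounds 2, 3 and 4.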